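The source may report more compounds than this note shows. Statements on the series, on what has been measured and on what is new or still open speak of the compounds shown alone.

In an assay on HEK293 cells for positive allosteric modulation of metabotropic glutamate receptor 5 (Homo sapiens), read by FLIPR, with a stated time of 1 h (on this read-out higher numbers stand for an effect only at larger amounts of compound and lower numbers for an effect already at smaller amounts), compound 1 `CCCCN1CCc2nc(C#Cc3ccccc3)sc2C1` gives 110 nM. Compound 2 `CCC(=O)N1CCc2nc(C#Cc3ccccc3)sc2C1` reaches only the limit of this assay, > 10000 nM. Compound 2 thus stands at the limit of > 10000 nM in this assay, at which 1 of the 2 values shown sits, and the step of an at least 90-fold higher number from compound 1 to compound 2 (1.95 log units; beyond the scatter) is the only measured one. Compound 3 `O=C(C1CCC1)N1CCc2nc(C#Cc3ccccc3)sc2C1` differs from compound 2 by cyclobutyl in place of ethyl on a carbonyl carbon, so the amide of compound 2 is kept. Going by the values given here, no measured step covers this change; the single step recorded concerns the amide itself. Compound 3 is expected to remain near the limit, with a step that the limit leaves unreadable from compound 2 to compound 3 expected within the scatter. Compound 3 is estimated at 15000 nM, between 4000 nM and 50000 nM.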

Compound 3, half-maximal effective concentration: > 10000 nM
Compound 3 ended at the assay's limit; the forecaster's own chance of this, stated with the estimate: 75%; the middle value does not contradict the limit.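

In this assay compound 3 gives > 10000 nM, which is a limit of the assay, so the larger cyclobutyl on the carbonyl carbon brings no readable value back, and the step from compound 2 cannot be read. Cyclobutylcarbonyl in place of butyl gives an at least 90-fold higher number from compound 1 to compound 3 (1.95 log units; beyond the scatter), so the loss now goes with a second carbonyl group on this nitrogen, not with propanoyl alone: the limit of > 10000 nM in this assay, at which 2 of the 3 values shown sit.

As far as these compounds go, whether a benzyl group or a shorter or longer alkyl chain on this nitrogen would keep a readable value stays open. So does what a sulfonyl group or a urea would do there.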